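The source may report more compounds than this note shows. Statements on the series, on what has been measured and on what is new or still open speak of the compounds shown alone.

Compound 2 `Cc1cc(-c2ccc(Cl)cc2Cl)c(S(C)(=O)=O)cc1C(=O)N=C(N)N` carries a 2,4-dichlorophenyl group on its aromatic core. For the measured compounds named here, in a functional assay for inhibition of sodium/hydrogen exchanger (Oryctolagus cuniculus) (a higher number here means a weaker inhibitor, a lower number a stronger inhibitor), compound 2 gives 42 nM, the higher of the two numbers known so far. Going by the values given here, its only neighbour is compound 1 `Cc1cc(C2CCC2)c(S(C)(=O)=O)cc1C(=O)N=C(N)N`, which in this assay gives 8.2 nM; the difference between them is a 5.1-fold higher number from compound 1 to compound 2 (0.71 log units; beyond the scatter). Compound 3 `Cc1cc(-c2ccc(F)cc2)c(S(C)(=O)=O)cc1C(=O)N=C(N)N` is compound 2 with 4-fluorophenyl in place of 2,4-dichlorophenyl on an aromatic carbon. Among the compounds with values here, no measured step compares two aromatic rings at this position, so the only guidance is the step from cyclobutyl to the dichlorinated ring, which pushed the number up. The entering ring carries a single fluorine where the leaving ring carried two chlorines, so the number for compound 3 is expected to drift somewhat back toward compound 1, though a shift within the scatter would not surprise. The step from compound 2 to compound 3 is therefore estimated at a 1.7-fold lower number from compound 2 to compound 3 (0.23 log units; within the scatter). Compound 3 is expected to give about 25 nM, with a range from 8 nM to 80 nM.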

Compound 3, half-maximal inhibitory concentration: 36 nM
Estimate against measurement, compound 3: 1.4-fold (0.16 log units) below; measured number inside the range.
By their numbers in this assay, from the lowest: compound 1; then compounds 3 and 2 (each within the scatter of the next).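

Exchanging 2,4-dichlorophenyl for 4-fluorophenyl on this aromatic carbon, ortho to a methylsulfonyl group, gives a 1.2-fold lower number from compound 2 to compound 3 (0.07 log units; within the scatter) and so leaves the two rings indistinguishable in this assay. Set against cyclobutyl, the new ring shows a 4.4-fold higher number from compound 1 to compound 3 (0.64 log units; beyond the scatter). The higher number relative to compound 1 is therefore not confined to the dichlorinated ring: both substituted phenyl groups shown share it, and neither compound goes against this, though no measurement at hand says what lies behind it.

From the compounds shown here alone, it remains open whether an unsubstituted phenyl ring would sit with compound 2 and compound 3, and whether a cyclopentyl ring would match compound 1. Also open, going by these compounds, is how this position responds to a group of a different kind, such as an amine or a carboxylic acid.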